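A few compounds are considered here, and "the series" means these few. Any claim that something is new, unique, unknown or untested is made for them only; others in the source may bear on it.

Compound 2 `COCCN1C(N)=NC(N)=NC12CCN(C(=O)c1cccn1C)CC2` carries a (1-methyl-1H-pyrrol-2-yl)carbonyl group on an amine nitrogen in a ring of the shared core. In an ADME assay on HeLa cells (Homo sapiens) for cytotoxicity, read by microscopy, with a stated time of 6 days (a higher number here means that more compound is tolerated, a lower number that less compound is tolerated), compound 2 gives > 100000 nM, which is a limit of the assay and not a number. Compound 1 `COCCN1C(N)=NC(N)=NC12CCN(C(=O)C1CC1)CC2`, with cyclopropyl on the carbonyl carbon, gives > 100000 nM in this assay, again a limit. Compound 3 `COCCN1C(N)=NC(N)=NC12CCN(C(=O)NC1CCC(C)CC1)CC2`, with (4-methylcyclohexyl)amino on the carbonyl carbon, gives > 100000 nM in this assay, also a limit. Going by the values given here, because of the limit of > 100000 nM in this assay, at which 3 of the 3 values shown sit, none of the measured steps can be read: a step that the two limits leave unreadable from compound 1 to compound 2, a step that the two limits leave unreadable from compound 1 to compound 3 and a step that the two limits leave unreadable from compound 2 to compound 3 all remain hidden behind the two limits.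

Compound 4 `CCS(=O)(=O)N1CCC2(CC1)N=C(N)N=C(N)N2CCOC` differs from compound 2 in one place: ethylsulfonyl in place of (1-methyl-1H-pyrrol-2-yl)carbonyl on an amine nitrogen in a ring. The three measured steps bear on this change only in one way: three quite different groups on the amine nitrogen in a ring never brought a value inside the measurable range of this assay. Among the compounds with values here, no step of readable size is therefore expected in this assay, in either direction, and the expectation is that compound 4 also stays at the limit. Compound 4 is estimated at 100000 nM, with a range from 30000 nM to 300000 nM, which means an expected step of a number no higher from compound 2 to compound 4 (the limit leaves the size open).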

Compound 4, minimum cytotoxic concentration: > 100000 nM
Compound 4: no number, only a limit (the forecaster's own chance of this, stated with the estimate: 85%); the middle value lies on the limit itself.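

No new step can be read from compound 4 to compound 2 or compound 1 in this assay, because every result stops at the same limit: the limit of > 100000 nM in this assay, at which 4 of the 4 values shown sit.

The compounds shown leave open at what concentration any of them would become toxic to the cells, and whether the different groups on the amine nitrogen in a ring change that concentration.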